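A Flipped Ring Carbon on a Weak Cytotoxic Amide

This account rests on a few compounds, and the source may have more. Where it says the series, first, only, none or still open, it means among the compounds named here.

Compound 1 `COc1cc([C@H]2C[C@]2(CO)C(=O)Nc2ccccc2Cl)cc(OC)c1OC` was tested in a functional assay on HeLa cells (Homo sapiens) for cytotoxicity, read by MTT assay, with a stated time of 48 h (on this read-out higher numbers stand for weaker inhibition and lower numbers for stronger inhibition), where compound 1 gives 45500 nM. Compound 2 `COc1cc([C@H]2C[C@]2(CO)C(=O)NCc2ccc(C)cc2)cc(OC)c1OC` gives 57800 nM in this assay, and the step of a 1.3-fold higher number from compound 1 to compound 2 (0.10 log units; within the scatter) leaves the two indistinguishable. Compound 3 `COc1cc([C@H]2C[C@]2(CO)C(=O)Nc2ccccc2)cc(OC)c1OC` reaches only > 100000 nM, which is a limit of the assay rather than a number (the limit of > 100000 nM in this assay, at which 1 of the 3 values shown sits). The step of an at least 2.1-fold higher number from compound 1 to compound 3 (0.34 log units; beyond the scatter) is therefore at least modest, while the step of an at least 1.7-fold higher number from compound 2 to compound 3 (0.23 log units; that floor lies within the scatter) has a floor within the scatter. Among the numbers shown, compound 1 holds the lowest one, with compound 2 close by.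

Compound 4 `COc1cc([C@H]2C[C@@]2(CO)C(=O)Nc2ccccc2Cl)cc(OC)c1OC` keeps every atom and bond of compound 1: the two compounds have the same atoms and bonds and differ only in configuration as drawn: 1 of 2 stereo elements differ; a stereocentre at a saturated ring carbon is drawn S in compound 1 and R in compound 4. Within the data shown here, none of the measured steps touches a stereocentre; each of them alters the group on the amide nitrogen, so none bears directly on this change. A flipped configuration at the ring carbon may leave the value unchanged or raise it, so for compound 4 the estimate is 70000 nM, with a range from 25000 nM to 150000 nM. This amounts to an expected step of a 1.5-fold higher number from compound 1 to compound 4 (0.19 log units; within the scatter).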

Compound 4, half-maximal inhibitory concentration: > 100000 nM
Compound 4 was reported as a limit (the forecaster's own chance of this, stated with the estimate: 35%); middle value at least 1.4-fold (0.15 log units) from the limit.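

The step of an at least 2.1-fold higher number from compound 1 to compound 4 (0.34 log units; beyond the scatter) shows that in this assay the drawn configuration at this saturated ring carbon counts on its own, since nothing else changes: the fact that compounds 1 and 4 differ only in the configuration as drawn Every earlier step altered a group on the amide nitrogen or on its aromatic ring, so those compounds could not show whether this ring carbon mattered at all. Compound 4 gives > 100000 nM, which is a limit and not a number, and it joins compound 3 at that same limit: the limit of > 100000 nM in this assay, at which 2 of the 4 values shown sit.

Going by these compounds, how far compound 4 really lies from compound 1 stays open, as does whether the flipped carbon would count equally with the 4-methylbenzyl amide of compound 2. The compounds shown also leave open what a carboxylic acid or an amine would do in place of the hydroxymethyl group on the shared core.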